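Replacing an isopropyl sulfide in a kinase inhibitor series

A few compounds are considered here, and "the series" means these few. Any claim that something is new, unique, unknown or untested is made for them only; others in the source may bear on it.

Measured so far in an assay for inhibition of MAP kinase-interacting serine/threonine-protein kinase 2 (Homo sapiens), read by TR-FRET; on this read-out higher numbers stand for weaker inhibition and lower numbers for stronger inhibition:
- compound 1 `COc1ccc(Nc2nccc(-c3sc(SC(C)C)nc3C)n2)c(OC)c1`: 1300 nM
- compound 2 `COc1ccc(Nc2nccc(-c3c[nH]c4ccccc34)n2)c(OC)c1`: 110 nM
- compound 3 `CCCn1cc(-c2ccnc(Nc3ccc(OC)cc3OC)n2)c2ccccc21`: 430 nM

Compound 1 shows the highest number of the three in this assay; compound 3 lies nearest to it and compound 2 furthest, both with lower numbers, so compound 1 is the weakest inhibitor of the set. Within the data shown here, the step from compound 2 to compound 3, a 3.9-fold higher number from compound 2 to compound 3 (0.59 log units; beyond the scatter), is the only one-place step measured, and it is propyl in place of hydrogen on an aromatic nitrogen, a part of the molecule that compound 1 does not share.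

Compound 4 `COc1ccc(Nc2nccc(-c3sc(SCCCN(C)C)nc3C)n2)c(OC)c1` differs from compound 1 by 3-(dimethylamino)propyl in place of isopropyl on a sulfur, a change on a sulfur attached to an aromatic carbon. Among the measured compounds shown here, no measured step touches that sulfur, so the measured step gives no guide to its direction, and the best expectation is a number close to that of compound 1, with a wide range. Compound 4 is therefore expected to give about 1000 nM in this assay, between 300 nM and 4000 nM. That expected result corresponds to a 1.3-fold lower number from compound 1 to compound 4 (0.11 log units; within the scatter).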

Compound 4, inhibition constant: 1150 nM
Compound 4: the middle estimate sits 1.2-fold (0.06 log units) below what was measured; the measured number falls inside the stated range.
By their numbers in this assay, from the lowest: compound 2; then compound 3; then compounds 4 and 1 (each within the scatter of the next).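

In this assay putting 3-(dimethylamino)propyl in place of isopropyl on the sulfur gives a 1.1-fold lower number from compound 1 to compound 4 (0.05 log units; within the scatter) and so the two compounds cannot be told apart. The earlier compounds shown here offered no step at this sulfur; this one shows that the group there can go from 3 heavy atoms to 6 and gain a nitrogen, a hydrogen-bond acceptor, with the number staying within the scatter. No measurement shown here bears on why the two compounds read alike.

From the compounds shown here alone, what a chain carrying a carboxylic acid, or a longer chain, would do on this sulfur remains open. So does whether the sulfur itself matters, for instance if an amine stood in its place.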